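The source may hold more compounds than are shown below. What is called first, only, known or untested is meant among the compounds shown, and "the series" means these compounds.

Compound 1, whose structure is `COc1cc(-c2ccnc3cc(-c4ccc(C)c(C)c4)nn23)cc(OC)c1OC`, is one of three compounds examined in a functional assay on MCF7 cells (Homo sapiens) for inhibition, read by CCK-8 assay, with a stated time of 48 h (a higher number here means a weaker inhibitor, a lower number a stronger inhibitor), where compound 1 gives 26 nM. That puts compound 1 second highest of the three. Going by the values given here, the one stronger inhibitor is compound 2 `COc1cc(-c2ccnc3cc(-c4ccc5c(ccn5C)c4)nn23)cc(OC)c1OC`, which gives 3 nM; the weaker is compound 3 `C=Cc1ccc(-c2cc3nccc(-c4cc(OC)c(OC)c(OC)c4)n3n2)cc1`, which gives 193 nM. Both neighbours differ from compound 1 only in the group attached at the same aromatic carbon: an 8.7-fold lower number from compound 1 to compound 2 (0.94 log units; beyond the scatter), while a 7.4-fold higher number from compound 1 to compound 3 (0.87 log units; beyond the scatter).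

Compound 4 `COc1ccc(-c2cc3nccc(-c4cc(OC)c(OC)c(OC)c4)n3n2)cc1N` changes that same group again: 3-amino-4-methoxyphenyl in place of 3,4-dimethylphenyl on an aromatic carbon. Among the compounds with values here, neither measured step introduced this particular group, so they show only that swaps at this position move the number by a modest amount in either direction. Within the data shown here, the entering group carries one hydrogen-bond donor and two acceptors that the leaving group lacks, and no measured compound tells whether that helps or hurts. The expectation is therefore a step no larger than those seen, with the direction uncertain; compound 4 is expected at a 1.3-fold lower number from compound 1 to compound 4 (0.11 log units; within the scatter). As an estimate, compound 4 should give about 20 nM, within a range from 5 nM to 80 nM.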

Compound 4, half-maximal inhibitory concentration: 27 nM
For compound 4 the middle estimate is 1.4-fold (0.13 log units) below the measured one, and the stated range covers the measured number.
By their numbers in this assay, from the lowest: compound 2; then compounds 1 and 4 (each within the scatter of the next); then compound 3.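

Replacing 3,4-dimethylphenyl with 3-amino-4-methoxyphenyl gives a 1.0-fold higher number from compound 1 to compound 4 (0.02 log units; within the scatter) in this assay and so leaves compounds 1 and 4 indistinguishable, which shows that this position can accept a group carrying one hydrogen-bond donor and two acceptors without a measurable loss. The earlier compounds shown here could not show this, as none of their groups at this aromatic carbon carries an amino or methoxy substituent. Compound 4 also keeps the wide spread at this position in view, with a 7.1-fold lower number from compound 3 to compound 4 (0.85 log units; beyond the scatter) on replacing 4-vinylphenyl and a 9.0-fold higher number from compound 2 to compound 4 (0.95 log units; beyond the scatter) on replacing 1-methyl-1H-indol-5-yl, so the donor and acceptor counts alone do not settle the number here.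

Nothing available explains why these groups give the numbers they do. On these data alone, compound 4 brings in the amine and the methoxy group together, so it remains open how 3-aminophenyl or 4-methoxyphenyl alone would compare, or what a carboxylic acid in place of the amine would do.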